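This account rests on a few compounds, and the source may have more. Where it says the series, first, only, none or still open, it means among the compounds named here.

Measured in a physicochemical assay for solubility, read by nephelometry, measured as kinetic solubility, at pH 6.5, tested at 10 mg/mL; a lower number here means a less soluble compound, a higher number a more soluble compound:
compound 1 `Cc1ccccc1C(=O)Nc1cc(Cl)ccn1`: 12.5 ug/mL
compound 2 `Cc1ccccc1C(=O)Nc1ccc(C#N)cn1`: 6.3 ug/mL
compound 3 `Cc1ccccc1C(=O)Nc1cc(C#N)ccn1`: 25 ug/mL

Compound 3 at 25 ug/mL lies within the scatter of compound 1. Compound 2 at 6.3 ug/mL gives a lower number than compound 3, beyond the scatter. Compound 4 `Cc1ccnc(NC(=O)c2ccccc2C)c1` carries methyl in place of cyano on an aromatic carbon, opposite the ring nitrogen: methyl in place of cyano on an aromatic carbon. Among the compounds with values here, one measured step bears on this place: a 2.0-fold higher number from compound 1 to compound 3 (0.30 log units; within the scatter), with cyano in place of chloro. Within the data shown here, no measured compound carries methyl there, so the estimate stays wide. In this assay, no step beyond the scatter is expected. The expected step is a 1.3-fold lower number from compound 3 to compound 4 (0.10 log units; within the scatter). For compound 4 the estimated value is 20 ug/mL, with an expected range of 8 ug/mL to 50 ug/mL.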

Compound 4, solubility: 25 ug/mL
Beside the measured number, compound 4's estimate is 1.3-fold (0.10 log units) below it, and the stated range covers the measured number.
By their numbers in this assay, from the lowest: compounds 2, 1, 3 and 4 (each within the scatter of the next, the first and the last beyond it).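

At the aromatic carbon opposite the ring nitrogen, methyl now joins cyano and chloro, and in this assay the readings stay close: no change at the digits printed from compound 3 to compound 4 (within the scatter), and a 2.0-fold higher number from compound 1 to compound 4 (0.30 log units; within the scatter). Replacing cyano with methyl removes a triple bond and a hydrogen-bond acceptor, yet neither step lies beyond the scatter. No measurement here accounts for this flat result.

An amine or a carboxylic acid at this place could still test whether the flat result extends beyond these three groups. As far as these compounds go, how methyl would read elsewhere on the ring also remains open.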